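The source may hold more compounds than are shown below. What is called first, only, known or untested is meant among the compounds shown, and "the series" means these compounds.

Compound 1 `CCCCc1cnc(C(CCCO)Cc2ccc(-c3ccccc3C(=O)O)cc2)[nH]1` is the weakest of the three measured compounds in an in vitro functional assay on cells for agonist activity at Bombesin receptor subtype-3 (Homo sapiens), read by luminescence and calcium flux (on this read-out lower numbers stand for an effect already at smaller amounts and higher numbers for an effect only at larger amounts of compound), where compound 1 gives 1900 nM. The nearest measured compound is compound 3 `O=C(O)c1ccccc1-c1ccc(CCc2ncc(Cc3cccc(F)c3)[nH]2)cc1`, which in this assay gives 159 nM; the most distant is compound 2 `CC(C)(C)Cc1cnc(CCc2ccc(-c3ccccc3C(=O)O)cc2)[nH]1`, which in this assay gives 106 nM. Compound 4 `CCCCc1cnc(C(Cc2ccc(-c3ccccc3C(=O)O)cc2)C(C)C)[nH]1` differs from compound 1 at one place: isopropyl in place of 3-hydroxypropyl on a saturated chain carbon bound to an aromatic carbon and a saturated chain carbon. Among the measured compounds shown here, the only measured step between neighbours, a 1.5-fold higher number from compound 2 to compound 3 (0.18 log units; within the scatter), changes a group at a different place, on the saturated chain carbon bound to an aromatic carbon of the core, and so does not bear directly on the change from compound 1 to compound 4. For the measured compounds named here, compounds 2 and 3 carry no substituent at all on the chain carbon where compound 1 holds its 3-hydroxypropyl, and both give numbers well below that of compound 1, but no measured pair isolates the exchange of 3-hydroxypropyl for isopropyl. The expectation for compound 4 therefore rests on little: a moderate move toward lower numbers is expected, a 2.1-fold lower number from compound 1 to compound 4 (0.32 log units; beyond the scatter), with wide uncertainty. Compound 4 is estimated to give 900 nM in this assay, within a range of 250 nM to 3200 nM.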

Compound 4, half-maximal effective concentration: 4620 nM
Beside the measured number, compound 4's estimate is 5.1-fold (0.71 log units) below it; the measured number lies above the stated range.
By their numbers in this assay, from the lowest: compounds 2 and 3 (each within the scatter of the next); then compound 1; then compound 4.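

In this assay, isopropyl in place of 3-hydroxypropyl on a saturated chain carbon bound to an aromatic carbon and a saturated chain carbon gives a 2.4-fold higher number from compound 1 to compound 4 (0.39 log units; beyond the scatter), the only step shown that isolates a change at this position. It shows that the number at this position responds to the group it carries, and that for this one exchange the move is modest and toward a higher number, with the hydrogen-bond donor and acceptor of the 3-hydroxypropyl absent from the isopropyl that replaces it. No measurement at hand says why the number moves in this direction.

Among the compounds shown here, the exchange changes the hydroxyl, the chain length and the branching together, so the single step cannot tell these apart, and a plain unbranched propyl chain or a butyl chain without the hydroxyl would be needed to separate them. Also open, as far as these compounds go, is how this position would respond to a terminal amine or a carboxylic acid at the end of a propyl chain, or to a longer chain that keeps the terminal hydroxyl.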